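This account rests on a few compounds, and the source may have more. Where it says the series, first, only, none or still open, it means among the compounds named here.

Working notes on the series. Compound 1 `COc1ccccc1-n1cc(CN2C(=O)C[C@@H]3CC[C@@]2(C)C3(C)C)nn1` and compound 2 `CC1(C)[C@H]2CC[C@]1(C)N(Cc1cn(-c3ccccc3O)nn1)C(=O)C2` share the same core and differ only at the phenyl on the triazole nitrogen. In a functional assay on OVCAR-3 cells (Homo sapiens) for inhibition, read by MTT assay, with a stated time of 24 h (a lower number here means a stronger inhibitor, a higher number a weaker inhibitor), compound 1 gives 140 nM, and in this assay compound 2 gives 90 nM. The step of a 1.6-fold lower number from compound 1 to compound 2 (0.19 log units; within the scatter) comes from a hydrogen in place of a methyl on an oxygen on an aromatic ring. Compound 2 therefore holds the lower of the two numbers, though its gap to compound 1 is within the scatter, so no order between them is claimed.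

The next compound, compound 3 `COc1ccc(-n2cc(CN3C(=O)C[C@@H]4CC[C@@]3(C)C4(C)C)nn2)cc1`, differs from compound 2 by 4-methoxyphenyl in place of 2-hydroxyphenyl on an aromatic nitrogen. For the measured compounds named here, the only step so far, a 1.6-fold lower number from compound 1 to compound 2 (0.19 log units; within the scatter), touched the same oxygen and was small, and no measured pair tests the 4-methoxyphenyl itself. For compound 3 the step of a 1.7-fold higher number from compound 2 to compound 3 (0.22 log units; within the scatter) is therefore expected to stay within the scatter. Compound 3 is estimated at 150 nM, with a range from 60 nM to 400 nM.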

Compound 3, half-maximal inhibitory concentration: 250 nM
Compound 3: the middle estimate sits 1.7-fold (0.22 log units) below what was measured; the range from low to high includes it.
By their numbers in this assay, from the lowest: compounds 2, 1 and 3 (each within the scatter of the next, the first and the last beyond it).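

For the compounds shown here, the change to 4-methoxyphenyl from 2-hydroxyphenyl on the aromatic nitrogen gives a 2.8-fold higher number from compound 2 to compound 3 (0.44 log units; beyond the scatter) in this assay, the first step beyond the scatter, so the group at this position can shift the number, though modestly. This change differs at two points on the phenyl, and neither of the two single changes passes the scatter: 4-methoxyphenyl in place of 2-methoxyphenyl gives a 1.8-fold higher number from compound 1 to compound 3 (0.25 log units; within the scatter), and hydrogen in place of methyl on the oxygen gives a 1.6-fold lower number from compound 1 to compound 2 (0.19 log units; within the scatter). No outside measurement on these compounds bears on why the step arises.

The compounds shown leave open how a 4-hydroxyphenyl would stand against compound 2 and compound 3, which would separate the site of the oxygen from the hydrogen on it. Also open, going by these compounds, is how an amine or a carboxylic acid on this phenyl would read in this assay against these three numbers.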